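The source may report more compounds than this note shows. Statements on the series, on what has been measured and on what is new or still open speak of the compounds shown alone.

Of the compounds shown here, two have been measured so far in a functional assay on HT-29 cells (Homo sapiens) for cytotoxicity, read by MTT assay, with a stated time of 72 h; a lower number here means a stronger inhibitor of growth, a higher number a weaker inhibitor of growth. Compound 1 `C[Se]/C(=N\C(=O)c1cc2ccccc2s1)NC(=O)c1cc2ccccc2s1` gives 5620 nM. Compound 2 `C[Se]/C(=N\C(=O)c1cnc2ccccc2c1)NC(=O)c1cnc2ccccc2c1` gives 200 nM, the lowest of the two numbers; its nearest neighbour is compound 1, whose number stands higher by a margin beyond the usual scatter, so compound 2 is the stronger inhibitor of growth of the pair.

Compound 3 `CS/C(=N\C(=O)c1cnc2ccccc2c1)NC(=O)c1cnc2ccccc2c1` has not yet been measured. It differs from compound 2 in one place: a group of 2 heavy atoms (1 carbon, 1 sulfur; no ring) in place of a group of 2 heavy atoms (1 carbon, 1 selenium; no ring), on a carbon with a double bond to nitrogen. The two measured compounds do not share this exchange, so they give no direct guide to its effect, and the direction of the step in this assay has to be judged without a precedent. A modest weakening is expected, with the step in this assay estimated as a 3.0-fold higher number from compound 2 to compound 3 (0.48 log units; beyond the scatter). Compound 3 is therefore estimated at 600 nM, with a range from 150 nM to 2500 nM.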

Compound 3, concentration for 50% growth inhibition: > 100000 nM
Compound 3: only a limit was reported; the forecaster's own chance of this, stated with the estimate: 3%; at least 160-fold (2.22 log units) between middle value and limit.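

In this assay, replacing the selenium-bearing group on the carbon with a double bond to nitrogen with methylsulfanyl, while the rest of compound 2 stays the same, gives an at least 500-fold higher number from compound 2 to compound 3 (2.69 log units; beyond the scatter). Compound 3 carries only a limit of the assay and not a number, so this step gives a minimum size and not an exact one: the limit of > 100000 nM in this assay, at which 1 of the 3 values shown sits. The earlier compounds shown here both carry the same selenium group and could not show this, whereas this pair shows that exchanging selenium for sulfur at this position alone can have a large effect on growth inhibition.

As far as these compounds go, it remains open whether the same exchange would have a similar effect on the core of compound 1. Also open, from the compounds shown here alone, are how a longer chain on the selenium, such as an ethyl group, or a methoxy group in this place would read, and why this exchange has so large an effect.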